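Adding a methyl to the benzyloxy-bearing ring of compound 1

This account rests on a few compounds, and the source may have more. Where it says the series, first, only, none or still open, it means among the compounds named here.

Compound 1 `CC(NC(=O)N(C)S(=O)(=O)c1ccc(Cl)cc1)c1ccccc1OCc1ccccc1` was tested in a functional assay on thoracic aorta (Rattus norvegicus, strain Wistar), with a stated time of 15 min (a higher number here means that more compound is needed for the effect, a lower number that less compound is needed), where compound 1 gives 38400 nM. For the measured compounds named here, its only measured partner is compound 2 `CC(NC(=O)N(C)S(=O)(=O)c1ccccc1)c1ccccc1OCc1ccccc1`, which in this assay gives 21700 nM; the step of a 1.8-fold lower number from compound 1 to compound 2 (0.25 log units; within the scatter) lies within the scatter, so the two numbers do not separate compound 1 from compound 2.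

The new compound 3 `Cc1ccc(OCc2ccccc2)c(C(C)NC(=O)N(C)S(=O)(=O)c2ccc(Cl)cc2)c1` differs from compound 1 by methyl in place of hydrogen on an aromatic carbon. Going by the values given here, no measured step touches this part of the shared core: the single known step concerns a chloro on a different ring and was itself within the scatter. With nothing to point either way, the expectation for compound 3 is a step of no change at the digits printed from compound 1 to compound 3 (within the scatter), that is, none beyond the scatter. The estimated value for compound 3 in this assay is 38400 nM, within a range from 15000 nM to 100000 nM.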

Compound 3, half-maximal effective concentration: 142000 nM
Beside the measured number, compound 3's estimate is 3.7-fold (0.57 log units) below it; the whole stated range lies below it.
By their numbers in this assay, from the lowest: compounds 2 and 1 (each within the scatter of the next); then compound 3.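

For the compounds shown here, this is the first step in this assay to lie beyond the scatter: methyl in place of hydrogen gives a 3.7-fold higher number from compound 1 to compound 3 (0.57 log units; beyond the scatter), whereas the earlier change, on the chloro of the other ring, did not separate its two compounds. So this aromatic carbon, para to the benzyloxy group and meta to a large group, does respond to substitution, and a single added carbon is enough to raise the concentration needed. Nothing available explains why the number rises with this change.

On these data alone, it remains open whether a fluoro, a methoxy or a longer chain such as ethyl on this carbon would raise the number as well, or whether an amine or a carboxylic acid there would lower it. As far as these compounds go, it is equally open whether the methyl would have the same effect on compound 2, which carries hydrogen in place of the chloro.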